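This account rests on a few compounds, and the source may have more. Where it says the series, first, only, none or still open, it means among the compounds named here.

Measured in a functional assay on ACHN cells (Homo sapiens) for antiproliferative activity, read by sulforhodamine B assay; on this read-out higher numbers stand for weaker inhibition of growth and lower numbers for stronger inhibition of growth:
- compound 1 `CC(C)(C)CCOc1cccc(O)c1C(=O)/C=C/c1ccc(O)cc1`: 3140 nM
- compound 2 `CC(C)=CCOc1cccc(O)c1C(=O)/C=C/c1ccc(O)cc1`: > 30000 nM (a limit of the assay, not a number)

Compound 2 sits at the limit of > 30000 nM in this assay, at which 1 of the 2 values shown sits. Compound 3 `O=C(/C=C/c1ccc(O)cc1)c1c(O)cccc1OCC1CCCC1` is the next compound to read in this assay. Its difference from compound 2 is cyclopentyl in place of 2-methylprop-1-en-1-yl on a saturated chain carbon bound to an oxygen on an aromatic ring. In words, this is cyclopentyl in place of 2-methylprop-1-en-1-yl on a saturated chain carbon bound to an oxygen on an aromatic ring, or 3-methylbut-2-en-1-yl to cyclopentylmethyl when cut one bond further out.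

For the measured compounds named here, only one measured step bears on this place: an at least 9.5-fold higher number from compound 1 to compound 2 (0.98 log units; beyond the scatter), with 2-methylprop-1-en-1-yl in place of neopentyl. That step lies beyond the scatter, but its size is only a bound, and a single pair sets no rule. Like cyclopentyl, the neopentyl of compound 1 has no double bond, and compound 1 gives 3140 nM. On that ground, compound 3 is expected to fall nearer to compound 1 than to compound 2. The expected step is an at least 5.0-fold lower number from compound 2 to compound 3 (0.69 log units; beyond the scatter), towards stronger inhibition of growth. Compound 3 is estimated at 6000 nM, with an expected range of 1800 nM to 25000 nM.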

Compound 3, concentration for 50% growth inhibition: 3510 nM
The estimate for compound 3 lay 1.7-fold (0.23 log units) above the measured number, and the stated range covers the measured number.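

In this assay, compound 2 remains a limit of the assay and not a number: the limit of > 30000 nM in this assay, at which 1 of the 3 values shown sits. Cyclopentyl in place of 2-methylprop-1-en-1-yl gives an at least 8.5-fold lower number from compound 2 to compound 3 (0.93 log units; beyond the scatter) and so adds a second saturated group that reads clear of that limit, this one carrying a five-membered non-aromatic ring, where the earlier compounds offered only the open-chain neopentyl. Cyclopentyl in place of neopentyl gives a 1.1-fold higher number from compound 1 to compound 3 (0.05 log units; within the scatter) and so shows that, at this saturated chain carbon bound to an oxygen on an aromatic ring, the ring and the open chain cannot be told apart, leaving compound 2, the only one of the three with a double bond outside aromatic rings, as the one that stands apart.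

As far as these compounds go, the true size of the steps out of compound 2 stays open, as does whether the double bond alone sets compound 2 apart, which a saturated 3-methylbutyl group on the same oxygen would test directly. Also open, from the compounds shown here alone, is how a phenyl ring, a longer chain, or an amine or carboxylic acid at the end of the chain would read at this place.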